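This account rests on a few compounds, and the source may have more. Where it says the series, first, only, none or still open, it means among the compounds named here.

Of the compounds shown here, three have so far been measured in an assay on CHO cells for displacement of a labelled ligand from Substance-P receptor (Homo sapiens); a lower number here means a stronger inhibitor, a higher number a weaker inhibitor. Compound 1 `Fc1ccc(C2NCCOC23CCC(c2cccc(C(F)(F)F)c2)CO3)cc1` gives 513 nM. Compound 3 `Fc1ccc([C@@H]2NCCOC23COC[C@H](c2ccccc2)C3)cc1` gives 99 nM. Compound 2 `COc1ccc(OC)c([C@H]2COCC3(C2)OCCN[C@H]3c2ccc(F)cc2)c1` gives 16 nM, the lowest of the three numbers and therefore the strongest inhibitor among them; its gap to compound 3 lies beyond the scatter, and its gap to compound 1 is wider still. The three compounds share a core but differ from one another at several places at once, so none of these gaps can be traced to a single structural change.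

Compound 4 `COc1ccc(C(F)(F)F)cc1[C@H]1COCC2(C1)OCCN[C@H]2c1ccc(F)cc1` differs from compound 2 in one place only: trifluoromethyl in place of methoxy on an aromatic carbon. The change sits on an aromatic carbon of a six-membered aromatic ring of carbon only. Among the measured compounds shown here, no pair of measured compounds differs in just this way, so there is no measured step to lean on, and the expectation rests on compound 2 alone, which gives 16 nM. Compound 4 is expected to come in at about 10 nM, with a likely range from 3 nM to 40 nM. This amounts to an expected step of a 1.6-fold lower number from compound 2 to compound 4 (0.20 log units; within the scatter), small and close to the usual scatter, in the direction of a somewhat stronger inhibitor.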

Compound 4, half-maximal inhibitory concentration: 1.3 nM
Beside the measured number, compound 4's estimate is 7.7-fold (0.89 log units) above it; the whole stated range lies above it.
By their numbers in this assay, from the lowest: compound 4; then compound 2; then compound 3; then compound 1.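

At this aromatic carbon, para to a methoxy group and meta to a large group, trifluoromethyl in place of methoxy gives a 12-fold lower number from compound 2 to compound 4 (1.09 log units; beyond the scatter) in this assay. Among the compounds shown here, this is the first difference here that can be tied to a single structural change, and it shows that the group at this one place strongly affects the number, which the earlier compounds, differing at several places at once, could not show. The group that enters has more heavy atoms and no hydrogen-bond acceptor, yet the inhibitor gets stronger, and nothing measured on these compounds explains why.

On these data alone, a single step cannot separate the added heavy atoms from the lost hydrogen-bond acceptor, so it remains open whether a chlorine atom, a methyl group or a nitrile on the same carbon would give a number closer to that of compound 2 or that of compound 4. Also open, as far as these compounds go, is what an amine or a carboxylic acid at this place would do, and whether the same change would give a step of similar size with the other methoxy group replaced.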